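This account rests on a few compounds, and the source may have more. Where it says the series, first, only, none or still open, it means among the compounds named here.

Compound 1 `O=C(O)c1ccc(CCCN2C(=O)CC[C@@H]2CCC(O)Cc2ccc3ccccc3c2)s1`: 65 nM in an assay on HEK293 cells for binding affinity to prostaglandin E2 receptor EP4 subtype (Rattus norvegicus); a lower number here means a stronger inhibitor, a higher number a weaker inhibitor.
Compound 2 `O=C(O)CCCCCCN1C(=O)CC[C@@H]1CC[C@@H](O)Cc1cccc(-c2ccccc2)c1`: 337 nM in this assay.

Of these two numbers compound 1 holds the lower one, and its gap to compound 2 lies beyond the usual scatter. The unmeasured compound 3 `CCc1ccc(CC(O)CC[C@H]2CCC(=O)N2CCCc2ccc(C(=O)O)s2)cc1` differs from compound 1 in one place: 4-ethylphenyl in place of naphthalen-2-yl on a saturated chain carbon, two bonds along the chain from an oxygen on a saturated carbon. Among the measured compounds shown here, no pair of measured compounds shows this change, so its size is not known from the data. Compound 3 is expected to sit somewhat higher than compound 1, a step of a 2.5-fold higher number from compound 1 to compound 3 (0.39 log units; beyond the scatter) in this assay, beyond the scatter but modest. The estimate for compound 3 is 160 nM, with a range from 50 nM to 500 nM.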

Compound 3, half-maximal inhibitory concentration: 140 nM
Compound 3: the middle estimate sits 1.1-fold (0.06 log units) above what was measured, within the range that was stated.
By their numbers in this assay, from the lowest: compound 1; then compound 3; then compound 2.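

At this position, on a saturated chain carbon, two bonds along the chain from an oxygen on a saturated carbon, the single-ring 4-ethylphenyl replaces the two-ring naphthalen-2-yl at a modest cost in this assay (a 2.2-fold higher number from compound 1 to compound 3 (0.33 log units; beyond the scatter)). The position therefore accepts one aromatic ring in place of two, which compounds 1 and 2, differing in more than one place, could not show. No measurement at hand explains the step. As far as these compounds go, whether the loss follows from the missing ring or from the ethyl group stays open, as does how an unsubstituted phenyl or a 4-chlorophenyl would fare here.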